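This account rests on a few compounds, and the source may have more. Where it says the series, first, only, none or still open, it means among the compounds named here.

Three compounds share one core and differ only in the group attached to the carbonyl carbon. In an assay on CHO cells for displacement of a labelled ligand from adenosine receptor A3 (Homo sapiens) (on this read-out higher numbers stand for weaker inhibition and lower numbers for stronger inhibition), compound 1 `CCNC(=O)[C@H]1O[C@@H](n2cnc3c(NCc4cccc(I)c4)nc(Cl)nc32)[C@H](O)[C@@H]1O` gives 0.891 nM, compound 2 `O=C(NC1CCC1)[C@H]1O[C@@H](n2cnc3c(NCc4cccc(I)c4)nc(Cl)nc32)[C@H](O)[C@@H]1O` gives 18.2 nM, and compound 3 `O=C([C@H]1O[C@@H](n2cnc3c(NCc4cccc(I)c4)nc(Cl)nc32)[C@H](O)[C@@H]1O)N1CCOCC1` gives 513 nM. Compound 3 therefore stands highest of the three, and the steps that lead to it, a 580-fold higher number from compound 1 to compound 3 (2.76 log units; beyond the scatter) and a 28-fold higher number from compound 2 to compound 3 (1.45 log units; beyond the scatter), both lie beyond the scatter, as does a 20-fold higher number from compound 1 to compound 2 (1.31 log units; beyond the scatter). Compound 4 `O=C(NCc1cccc(Cl)c1)[C@H]1O[C@@H](n2cnc3c(NCc4cccc(I)c4)nc(Cl)nc32)[C@H](O)[C@@H]1O` carries (3-chlorobenzyl)amino in place of morpholin-4-yl on a carbonyl carbon. The two steps into compound 3 bear directly on this change, since each of them replaced a group with a hydrogen-bond donor by the morpholin-4-yl group and raised the number greatly; compound 4 reverses that kind of exchange, so a lower number is expected. The step from compound 1 to compound 2, however, shows that a bulkier group on the amide nitrogen raises the number, and the (3-chlorobenzyl)amino group is larger than cyclobutylamino. Compound 4 is thus estimated at 60 nM, within a range of 10 nM to 400 nM, an expected step of an 8.6-fold lower number from compound 3 to compound 4 (0.93 log units; beyond the scatter) in this assay.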

Compound 4, inhibition constant: 309 nM
Beside the measured number, compound 4's estimate is 5.2-fold (0.71 log units) below it, and the stated range covers the measured number.
By their numbers in this assay, from the lowest: compound 1; then compound 2; then compounds 4 and 3 (each within the scatter of the next).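

In this assay a hydrogen-bond donor in the group on this carbonyl carbon is not enough for a low number: a 1.7-fold lower number from compound 3 to compound 4 (0.22 log units; within the scatter) leaves (3-chlorobenzyl)amino and morpholin-4-yl not told apart, so compound 4 goes against the reading that the amide hydrogen alone separates compounds 1 and 2 from compound 3. What sits on the amide nitrogen therefore matters as well, as shown by a 17-fold higher number from compound 2 to compound 4 (1.23 log units; beyond the scatter) and by a 350-fold higher number from compound 1 to compound 4 (2.54 log units; beyond the scatter) in the comparisons with the cyclobutyl and ethyl amides. No measurement shown here explains these steps.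

On these data alone, it remains open whether benzylamino without the chlorine would give a number closer to that of compound 4 or to that of compound 2. As far as these compounds go, the numbers that methylamino or a longer straight chain such as n-propylamino would give on this carbonyl carbon also remain open.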